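Dropping a core methoxy from compound 3

This account rests on a few compounds, and the source may have more. Where it says the series, first, only, none or still open, it means among the compounds named here.

In a functional assay on CWR22R cells (Homo sapiens) for antiproliferative activity, read by luminescence, with a stated time of 96 h (a higher number here means a weaker inhibitor, a lower number a stronger inhibitor), compound 1 (`CC1(C)Oc2cc(NS(=O)(=O)C3CCCCC3)ccc2NC1=O`) gives 8020 nM and compound 2 (`CC1(C)Oc2cc(NS(=O)(=O)c3ccc(F)cc3Cl)ccc2NC1=O`) gives 7050 nM. Among the compounds with values here, the only measured step, a 1.1-fold lower number from compound 1 to compound 2 (0.06 log units; within the scatter), lies within the scatter and concerns the group on the sulfonyl sulfur. Compound 3 (`COc1cc2c(cc1NS(=O)(=O)c1cc(Br)ccc1OC)OC(C)(C)C(=O)N2`) has the lowest number of the three, at 3380 nM. Compound 4 (`COc1ccc(Br)cc1S(=O)(=O)Nc1ccc2c(c1)OC(C)(C)C(=O)N2`) keeps the sulfonyl group of compound 3 and changes the core: hydrogen in place of methoxy on an aromatic carbon. Within the data shown here, no measured step isolates this change, so the measured step gives no size for it. Compound 2, which also lacks this core methoxy, stands at 7050 nM, and that value points to a higher number. The expected step is a 2.1-fold higher number from compound 3 to compound 4 (0.32 log units; beyond the scatter). Compound 4 is estimated at 7000 nM, with an expected range of 3000 nM to 15000 nM.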

Compound 4, half-maximal inhibitory concentration: 4850 nM
For compound 4 the middle estimate is 1.4-fold (0.16 log units) above the measured one; measured number inside the range.
By their numbers in this assay, from the lowest: compounds 3, 4, 2 and 1 (each within the scatter of the next, the first and the last beyond it).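

The step of a 1.4-fold higher number from compound 3 to compound 4 (0.16 log units; within the scatter) gives the first measured size for hydrogen in place of methoxy on this aromatic carbon, ortho to a large group. With the sulfonyl group held constant, this assay shows no change beyond the scatter on losing this core methoxy. No measured evidence bears on the cause of this result.

On these data alone, an amine or a longer alkoxy chain at this position remains open. Also open, as far as these compounds go, is whether the step of a 1.4-fold higher number from compound 3 to compound 4 (0.16 log units; within the scatter) holds with the sulfonyl groups of compound 1 and compound 2.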